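The source may report more compounds than this note shows. Statements on the series, on what has been measured and on what is new or still open speak of the compounds shown alone.

Measured so far in a functional assay on MDA-MB-231 cells (Homo sapiens) for antiproliferative activity, read by sulforhodamine B assay; on this read-out higher numbers stand for weaker inhibition of growth and lower numbers for stronger inhibition of growth:
- compound 1 `CCCCOc1cccc(O)c1C(=O)/C=C/c1ccc(O)cc1`: > 30000 nM (a limit of the assay, not a number)
- compound 2 `CC(C)CCOc1cccc(O)c1C(=O)/C=C/c1ccc(O)cc1`: 10300 nM
- compound 3 `CCC(CC)COc1cccc(O)c1C(=O)/C=C/c1ccc(O)cc1`: 3130 nM

Compound 3 stands lowest of the three, with a 3.3-fold lower number from compound 2 to compound 3 (0.52 log units; beyond the scatter) and an at least 9.5-fold lower number from compound 1 to compound 3 (0.98 log units; beyond the scatter). Next in view is compound 4 `CC(C)COc1cccc(O)c1C(=O)/C=C/c1ccc(O)cc1`, which has isopropyl in place of pentan-3-yl on a saturated chain carbon bound to an oxygen on an aromatic ring. Cut one bond further out, this reads 2-ethylbutoxy to isobutoxy.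

The measured steps that bear on it all run one way, with an at least 2.9-fold lower number from compound 1 to compound 2 (0.46 log units; beyond the scatter) alongside the two above. Across these three compounds, a larger branched chain goes with a lower number, and none goes against this. Compound 4 takes back more of the chain than compound 2 does, so a reversal at least comparable to the step from compound 2 to compound 3 is expected. In this assay the expected step is a 4.2-fold higher number from compound 3 to compound 4 (0.62 log units; beyond the scatter), toward a higher number and beyond the scatter. For compound 4 the estimated value is 13000 nM, with an expected range of 5500 nM to 30000 nM.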

Compound 4, concentration for 50% growth inhibition: 3520 nM
For compound 4 the middle estimate is 3.7-fold (0.57 log units) above the measured one; the measured number lies below the stated range.
By their numbers in this assay, from the lowest: compounds 3 and 4 (each within the scatter of the next); then compound 2. At a limit, above all of these: compound 1.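

In this assay, setting isopropyl in place of pentan-3-yl on a saturated chain carbon bound to an oxygen on an aromatic ring gives a 1.1-fold higher number from compound 3 to compound 4 (0.05 log units; within the scatter), so at this position a much smaller branched group can read the same as the larger one. The earlier link between a larger branched chain and a lower number therefore does not hold across the series: compound 4 goes against it, with isopropyl in place of isobutyl giving a 2.9-fold lower number from compound 2 to compound 4 (0.47 log units; beyond the scatter). The remaining step, an at least 8.5-fold lower number from compound 1 to compound 4 (0.93 log units; beyond the scatter), rests on compound 1, whose value is a limit of the assay and not a number: the limit of > 30000 nM in this assay, at which 1 of the 4 values shown sits.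

Going by these compounds, what sets compound 2 apart from compounds 3 and 4 stays open on these values. Also open, on these data alone, is how a longer chain, a cyclohexylmethyl group or a terminal amine in this place would read.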